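Cytotoxicity Check Before a Vinyl Replaces the Methoxymethyl

The source may hold more compounds than are shown below. What is called first, only, known or untested is meant among the compounds shown, and "the series" means these compounds.

Compound 1 `CCCCSc1nc(N)nc2c1ncn2/C=C1/CC1(CO)CO` and compound 2 `COCCOc1nc(N)nc2c1ncn2/C=C1/CC1(CO)CO` share one core and differ at a single spot. In an ADME assay on HFF cells (Homo sapiens) for cytotoxicity, with a stated time of 8 days (on this read-out lower numbers stand for higher toxicity in this test and higher numbers for lower toxicity in this test), compound 1 gives only a limit of the test, > 300000 nM. In this assay compound 2 likewise gives only a limit, > 300000 nM. The step that the two limits leave unreadable from compound 1 to compound 2 therefore cannot be sized, because of the limit of > 300000 nM in this assay, at which 2 of the 2 values shown sit. Compound 2 thus stands at the boundary of what this assay can report, with no number of its own behind it. Compound 3 `C=CCOc1nc(N)nc2c1ncn2/C=C1/CC1(CO)CO` has not yet been measured; it differs from compound 2 in one place: vinyl in place of methoxymethyl on a saturated chain carbon bound to an oxygen on an aromatic ring. For the measured compounds named here, the only measured step bears on this change but shows no readable size, so no shift beyond the scatter in this assay is expected. Compound 3 is expected to sit again at the limit, estimated at 300000 nM within 100000 nM to 600000 nM. The step of a number no higher from compound 2 to compound 3 (the limit leaves the size open) is expected to be nil.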

Compound 3, half-maximal cytotoxic concentration: > 300000 nM
Compound 3: no number, only a limit; the forecaster's own chance of this, stated with the estimate: 80%; the middle value sits exactly at the limit.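

For the compounds shown here, no step between compound 1, compound 2 and compound 3 can be read in this assay, as each gives only a limit of the test: the limit of > 300000 nM in this assay, at which 3 of the 3 values shown sit. The compounds shown leave open whether butylsulfanyl, 2-methoxyethoxy or allyloxy changes cytotoxicity at all, and at what concentration any of the three would become toxic.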